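Shortening the chain on the ring nitrogen of compound 2

A few compounds are considered here, and "the series" means these few. Any claim that something is new, unique, unknown or untested is made for them only; others in the source may bear on it.

Among the compounds with values here, compound 2 `CC(C)=CCn1nc(-c2cccnc2)c2ccccc2c1=O` is one of three compounds measured in an assay on isolated protein (Oryctolagus cuniculus) with Thromboxane-A synthase (Homo sapiens) as the target, tested at 1 uM (a higher number here means more inhibition at the concentration tested (going by the name of the read-out), a lower number less inhibition), where compound 2 gives 94%. It stands second highest: compound 3 `O=c1c2ccccc2c(-c2cccnc2)nn1CC1CCCCC1` gives 98%, and the step of a number 4 percentage points higher from compound 2 to compound 3 (within the scatter) lies within the scatter, so the two cannot be ordered. Compound 1 `C=CCn1nc(-c2cccnc2)c2ccccc2c1=O` gives 70%, and the step of a number 24 percentage points higher from compound 1 to compound 2 (beyond the scatter) is beyond the scatter, as is a number 28 percentage points higher from compound 1 to compound 3 (beyond the scatter).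

Compound 4 `O=c1c2ccccc2c(-c2cccnc2)nn1CCO` has not yet been measured. Relative to compound 2 the change is hydroxymethyl in place of 2-methylprop-1-en-1-yl on a saturated chain carbon bound to an aromatic nitrogen. Of the measured steps, a number 24 percentage points higher from compound 1 to compound 2 (beyond the scatter) bears most directly on it, since compound 1 carries vinyl at the same place and the entering hydroxymethyl is likewise counted at two heavy atoms; a number 4 percentage points higher from compound 2 to compound 3 (within the scatter) shows that exchanging one group of four or more heavy atoms for another at this place left the number unchanged. Within the data shown here, no measured compound carries a hydrogen-bond donor or acceptor on this chain.

A drop of about the size seen in the step of a number 24 percentage points higher from compound 1 to compound 2 (beyond the scatter) is therefore expected. The expected step is a number 28 percentage points lower from compound 2 to compound 4 (beyond the scatter). Compound 4 is estimated at 66%, with a range from 45% to 85%.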

Compound 4, a percentage reported as inhibition, at one concentration (the size of the read-out at that concentration, not a potency): 69%
For compound 4 the middle estimate is 3 percentage points below the measured one; low and high end bracket the measured number.
By their numbers in this assay, from the lowest: compounds 4 and 1 (each within the scatter of the next); then compounds 2 and 3 (each within the scatter of the next).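

Hydroxymethyl on the saturated chain carbon bound to the aromatic nitrogen reads the same as vinyl in this assay, since the step of a number 1 percentage points lower from compound 1 to compound 4 (within the scatter) gives the two groups no order. Both larger groups stand clearly apart from it, with a number 25 percentage points lower from compound 2 to compound 4 (beyond the scatter) and a number 29 percentage points lower from compound 3 to compound 4 (beyond the scatter), so the four compounds now fall into two pairs, the smaller groups in compounds 1 and 4 and the larger ones in compounds 2 and 3, and none of the four goes against this split. Hydroxymethyl is also the first group at this place to carry a hydrogen-bond donor and acceptor, yet the number for compound 4 cannot be told from that for compound 1, which has neither.

No measurement on hand explains why the larger groups stand apart from the smaller ones. Going by these compounds, with size and the hydroxyl group not yet separated at this place, it remains open how a longer chain ending in a hydroxyl group, a longer plain alkyl chain, an amine or a carboxylic acid would read.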